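Moving the attachment point from compound 3 to compound 4

The compounds below may be only part of what the source reports. "The series", "measured", "known", "first", "only" and "open" are said of these compounds alone.

Compound 3 `c1ccc2c(c1)CC(CCN1CCN(c3cccc4c3OCCO4)CC1)C2` carries a 2,3-dihydro-1H-inden-2-yl group; in an assay for activation of Adrenergic receptor alpha-1 (Rattus norvegicus) (on this read-out lower numbers stand for an effect already at smaller amounts and higher numbers for an effect only at larger amounts of compound), compound 3 gives 0.66 mg/kg, the second highest of three numbers. Compound 1 `C1=C(CCN2CCN(c3cccc4c3OCCO4)CC2)Cc2ccccc21` gives 0.17 mg/kg, and compound 2 `Clc1cccc2c1CC2CCN1CCN(c2cccc3c2OCCO3)CC1` gives 20 mg/kg. Compound 4 `c1ccc2c(c1)CCC2CCN1CCN(c2cccc3c2OCCO3)CC1` differs from compound 3 at one place only: 2,3-dihydro-1H-inden-1-yl in place of 2,3-dihydro-1H-inden-2-yl on a saturated chain carbon, two bonds along the chain from an amine nitrogen in a ring. Within the data shown here, the closest precedent is the earlier exchange of the group at this same position, a 3.9-fold higher number from compound 1 to compound 3 (0.59 log units; beyond the scatter), a modest shift, whereas swapping in a chlorine-bearing group, a 120-fold higher number from compound 1 to compound 2 (2.07 log units; beyond the scatter), was large. Because the step of a 3.9-fold higher number from compound 1 to compound 3 (0.59 log units; beyond the scatter) was modest, a modest step is expected here as well, in either direction. Compound 4 is therefore estimated at 0.5 mg/kg, between 0.15 mg/kg and 2 mg/kg, which means an expected step of a 1.3-fold lower number from compound 3 to compound 4 (0.12 log units; within the scatter).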

Compound 4, dose for half-maximal effect: 4.01 mg/kg
For compound 4 the middle estimate is 8.0-fold (0.90 log units) below the measured one; the measured number lies above the stated range.
By their numbers in this assay, from the lowest: compound 1; then compound 3; then compound 4; then compound 2.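

Joining the same atoms differently is enough to change the result in this assay: 2,3-dihydro-1H-inden-1-yl in place of 2,3-dihydro-1H-inden-2-yl gives a 6.1-fold higher number from compound 3 to compound 4 (0.78 log units; beyond the scatter) at this position. The new group also sits apart from the other two earlier groups, with a 24-fold higher number from compound 1 to compound 4 (1.37 log units; beyond the scatter) and a 5.0-fold lower number from compound 2 to compound 4 (0.70 log units; beyond the scatter) in the same read-out. Nothing measured here explains the shift.

Still open, as far as these compounds go, is whether a hydroxyl or methyl group on the 2,3-dihydro-1H-inden-1-yl group would move the number further. From the compounds shown here alone, the effect of a longer chain to the amine nitrogen in a ring also remains unknown.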